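Aryl swap on the benzylic side chain: compound 2 to compound 4

The source may report more compounds than this note shows. Statements on the series, on what has been measured and on what is new or still open speak of the compounds shown alone.

Measured compounds:
compound 1 `Cc1ccc(CC(CNC(=O)C(C)(C)c2ccc(NS(C)(=O)=O)cc2)COC(=O)C(C)(C)C)cc1C` — 370 nM
compound 2 `CC(C(=O)NCC(COC(=O)C(C)(C)C)Cc1ccc(C(C)(C)C)cc1)c1ccc(NS(C)(=O)=O)cc1` — 55 nM
compound 3 `COc1cc(C(C)C(=O)NCC(COC(=O)C(C)(C)C)Cc2ccc(C(C)(C)C)cc2)ccc1NS(C)(=O)=O` — 24 nM

In an assay on CHO cells for displacement of a labelled ligand from transient receptor potential cation channel subfamily V member 1 (Rattus norvegicus) (on this read-out lower numbers stand for stronger inhibition and higher numbers for weaker inhibition), compound 2 stands second highest of the three numbers; compound 3 sits nearest, with a 2.3-fold lower number from compound 2 to compound 3 (0.36 log units; beyond the scatter), and compound 1 furthest, with a higher number. Compound 4 `Cc1ccc(CC(CNC(=O)C(C)c2ccc(NS(C)(=O)=O)cc2)COC(=O)C(C)(C)C)cc1C` differs from compound 2 only by 3,4-dimethylphenyl in place of 4-(tert-butyl)phenyl on a saturated chain carbon, three bonds along the chain from an amide-type nitrogen and an oxygen next to a carbonyl group. Among the compounds with values here, the one measured step, from compound 2 to compound 3, concerns the methoxy and does not bear on this change. Compound 1, the sole measured carrier of the 3,4-dimethylphenyl, differs from compound 2 in two places, so its higher number is only indirect guidance. A weakening step is therefore expected for compound 4, a 3.6-fold higher number from compound 2 to compound 4 (0.56 log units; beyond the scatter), with a wide range. Compound 4 is estimated at 200 nM, between 70 nM and 600 nM.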

Compound 4, inhibition constant: 119 nM
For compound 4 the middle estimate is 1.7-fold (0.23 log units) above the measured one, within the range that was stated.
By their numbers in this assay, from the lowest: compound 3; then compound 2; then compound 4; then compound 1.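

In this assay, the aryl swap gives a direct reading at this position: a 2.2-fold higher number from compound 2 to compound 4 (0.34 log units; beyond the scatter), so the 3,4-dimethylphenyl group keeps measurable binding but sits on the weaker side of 4-(tert-butyl)phenyl. The change on the saturated chain carbon bound to an aromatic carbon, a carbonyl carbon and a saturated chain carbon can now be read separately, with hydrogen in place of methyl giving a 3.1-fold lower number from compound 1 to compound 4 (0.49 log units; beyond the scatter). No measurement available here accounts for either step.

Going by these compounds, whether the methoxy step seen with 4-(tert-butyl)phenyl carries over to 3,4-dimethylphenyl remains open. So does the outcome with a cyclohexyl or 4-chlorophenyl group at this position.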